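Bromo for Chloro in a Series Without Measurable Cytotoxicity

The compounds below may be only part of what the source reports. "The series", "measured", "known", "first", "only" and "open" are said of these compounds alone.

Compound 3 `Fc1ccc(-c2nc3c(NC4CCCC4)cc(Cl)cn3c2-c2ccnc(NC3CCCC3)n2)cc1` is one of three compounds sharing a common core that have been examined in an ADME assay on Vero cells (Chlorocebus sabaeus) for cytotoxicity; a lower number here means that less compound is tolerated, a higher number that more compound is tolerated. In this assay compound 3 gives > 40000 nM, which is a limit of the assay rather than a number. Compound 1 `Fc1ccc(-c2nc3ccc(Br)cn3c2-c2ccnc(NC3CCCC3)n2)cc1` gives > 40000 nM in this assay, again a limit. Compound 2 `Fc1ccc(-c2nc3c(Cl)cc(Cl)cn3c2-c2ccnc(NC3CCCC3)n2)cc1` gives > 40000 nM in this assay, also a limit. Among the compounds with values here, the only step between measured compounds that differ in one place, cyclopentylamino in place of chloro on an aromatic carbon, is a step that the two limits leave unreadable from compound 2 to compound 3; this follows from the limit of > 40000 nM in this assay, at which 3 of the 3 values shown sit.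

Compound 4 `Fc1ccc(-c2nc3c(NC4CCCC4)cc(Br)cn3c2-c2ccnc(NC3CCCC3)n2)cc1` has not yet been measured. It differs from compound 3 by bromo in place of chloro on an aromatic carbon. Within the data shown here, no measured step exchanges one halogen for another, so none bears directly on this change; the nearest pointer is that compound 1 carries bromo and compound 2 carries chloro, and neither returned a readable number. Compound 4 is therefore expected to give an estimated 50000 nM in this assay, with a range from 25000 nM to 100000 nM. The expected step is a step that the limit leaves unreadable from compound 3 to compound 4, nothing beyond the scatter.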

Compound 4, half-maximal cytotoxic concentration: > 40000 nM
Compound 4: a limit, no number; the forecaster's own chance of this, stated with the estimate: 85%; the middle value lies beyond the limit too.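

In this assay, within the data shown here, compound 4 gives > 40000 nM as a limit and not a number, so no step from compound 3 or compound 1 to compound 4 can be read: the limit of > 40000 nM in this assay, at which 4 of the 4 values shown sit.

The compounds shown leave open at what concentration any of them becomes cytotoxic, and whether bromo and chloro differ at all in this respect.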